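A few compounds are considered here, and "the series" means these few. Any claim that something is new, unique, unknown or untested is made for them only; others in the source may bear on it.

Compound 3 `C#CCN(CCCCOc1ccc2ccc(=O)oc2c1)Cc1ccc(C)cc1` carries a four-carbon chain between the shared core and the amine and a 4-methylbenzyl group on that amine. In an assay on isolated protein for inhibition of Amine oxidase [flavin-containing] B (Homo sapiens), read by fluorescence and Amplex Red, with stated times of 15 min and 20 min (a higher number here means a weaker inhibitor, a lower number a stronger inhibitor), compound 3 gives 1680 nM. Its closest neighbour in the series is compound 2 `C#CCN(CCCCOc1ccc2ccc(=O)oc2c1)Cc1ccc(OC)cc1`, which in this assay gives 1130 nM; the two are separated only by a 1.5-fold higher number from compound 2 to compound 3 (0.17 log units; within the scatter). Compound 1 `C#CCN(CCCOc1ccc2ccc(=O)oc2c1)Cc1ccccc1`, with a three-carbon chain and an unsubstituted benzyl group, gives 3740 nM in this assay, a number that stands beyond the scatter from that of compound 3.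

Compound 4 `C#CCN(CCCCOc1ccc2ccc(=O)oc2c1)Cc1ccccc1` differs from compound 3 in one place: hydrogen in place of methyl on an aromatic carbon. For the measured compounds named here, of the measured steps, only that from compound 2 to compound 3 touches the same aromatic carbon, and it stayed within the scatter when a methyl replaced a methoxy. Compounds 1 and 4 share the benzyl group but not the chain length, so their values cannot be compared as a single change. On this basis the step of a 1.3-fold higher number from compound 3 to compound 4 (0.10 log units; within the scatter) is expected to stay within the scatter, or at most to give a modestly higher number. Compound 4 is therefore estimated at 2100 nM in this assay, with a range from 900 nM to 4800 nM.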

Compound 4, half-maximal inhibitory concentration: 978 nM
Estimate against measurement, compound 4: 2.1-fold (0.33 log units) above; low and high end bracket the measured number.
By their numbers in this assay, from the lowest: compounds 4, 2 and 3 (each within the scatter of the next); then compound 1.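

Hydrogen in place of methyl on the aromatic carbon para to a large group gives a 1.7-fold lower number from compound 3 to compound 4 (0.23 log units; within the scatter) in this assay, so removing the methyl of the 4-methylbenzyl group to leave a plain benzyl group does not take the number beyond the scatter. Hydrogen in place of methoxy at that carbon gives a 1.2-fold lower number from compound 2 to compound 4 (0.06 log units; within the scatter), so with the four-carbon chain in place, the unsubstituted ring now joins the two substituted ones and hydrogen, methyl and methoxy cannot be told apart in this assay, a reading that the earlier comparison of methyl with methoxy alone could not give. No supporting data are available to account for this result.

From the compounds shown here alone, whether a chlorine, a nitrile or a carboxylic acid on the same aromatic carbon would move the number beyond the scatter remains open, since the three groups compared here span only a narrow set. Going by these compounds, it is also open whether the same insensitivity holds with a three-carbon chain, which appears here only in compound 1 with its unsubstituted benzyl group, at 3740 nM.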